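Nitro in place of hydrogen: cytotoxicity notes

This account rests on a few compounds, and the source may have more. Where it says the series, first, only, none or still open, it means among the compounds named here.

Compound 3 `CC(=O)Nc1ccc(-c2nc3ccccc3[nH]2)cc1` heads the first pair. In an ADME assay on MDBK cells (Bos taurus) for cytotoxicity, read by MTT assay, with a stated time of 96 h (on this read-out higher numbers stand for lower toxicity in this test and lower numbers for higher toxicity in this test), compound 3 gives > 100000 nM, which is a limit of the assay rather than a number. Compound 1 `CC(=O)Nc1ccc(-c2nc3cc([N+](=O)[O-])ccc3[nH]2)cc1` carries nitro in place of hydrogen on an aromatic carbon. In this assay compound 1 gives > 100000 nM, again a limit. The step that the two limits leave unreadable from compound 3 to compound 1 cannot be read, because of the limit of > 100000 nM in this assay, at which 3 of the 3 values shown sit. Compound 2 `COc1ccc(-c2nc3cc(C(F)(F)F)ccc3[nH]2)cc1` rests on a different core; how its core differs from that of compound 3 is not broken down here. In this assay compound 2 gives > 100000 nM, also a limit. Compound 4 `COc1ccc(-c2nc3cc(C(F)(F)F)ccc3[nH]2)c([N+](=O)[O-])c1` is not yet measured and carries nitro in place of hydrogen on an aromatic carbon. This is the same kind of change as in the first pair, not the same change: there the nitro entered on a ring that is part of a fused system, meta to a fused ring and para to a fused ring, whereas here it enters ortho to a large group and meta to a methoxy group. In this assay the step of a number no higher from compound 2 to compound 4 (the limit leaves the size open) is expected to be near nothing. That expectation rests on compound 2 with its limit > 100000 nM. It also rests on the step that the two limits leave unreadable from compound 3 to compound 1, which stays unreadable. Compound 4 is therefore estimated at 100000 nM, between 30000 nM and 300000 nM.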

Compound 4, half-maximal cytotoxic concentration: 55000 nM
Estimate against measurement, compound 4: 1.8-fold (0.26 log units) above, within the range that was stated.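

In this assay, from the compounds shown here alone, nitro in place of hydrogen on the core of compound 2 gives an at least 1.8-fold lower number from compound 2 to compound 4 (0.25 log units; that floor lies within the scatter), so on this core the change brings a limit down to a readable value, though its true size remains open. The matching step on the core of compound 3 cannot be read, because neither of its ends is a number: the limit of > 100000 nM in this assay, at which 3 of the 4 values shown sit. The series therefore shows one floor on one core and no evidence that the change carries over in size or direction, and the two nitro groups also sit differently, with that of compound 4 ortho to a large group and meta to a methoxy group.

The compounds shown leave open whether an amine or a carboxylic acid in place of the nitro on the core of compound 2 would also give a readable value. They also leave open how far the step depends on where the nitro stands on each core.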